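The compounds below may be only part of what the source reports. "The series", "measured", "known", "first", "only" and "open" are said of these compounds alone.

Compound 1 `CC(C(=O)N1CC2CC2C1)N1CCN(S(=O)(=O)c2ccc(C(C)(C)C)cc2)CC1` carries a bicyclic amide on the shared core; in an ADME assay on HepG2 cells (Homo sapiens) for inhibition, with a stated time of 48 h (a lower number here means that less compound is needed, a higher number that more compound is needed for the effect), compound 1 reaches only a limit, > 40000 nM. Compound 2 `CC(C(=O)N1CCCCC1)N1CCN(S(=O)(=O)c2ccc(C(C)(C)C)cc2)CC1` likewise gives only a limit in this assay, with compound 2 at > 40000 nM. Compound 3 `CC(C(=O)N1CCc2ccccc21)N1CCN(S(=O)(=O)c2ccc(C(C)(C)C)cc2)CC1` also stops at a limit, compound 3 giving > 40000 nM. The steps a step that the two limits leave unreadable from compound 1 to compound 2, a step that the two limits leave unreadable from compound 1 to compound 3 and a step that the two limits leave unreadable from compound 2 to compound 3 cannot be sized, because of the limit of > 40000 nM in this assay, at which 3 of the 3 values shown sit. Compound 4 `CC(C(=O)N1Cc2ccccc2C1)N1CCN(S(=O)(=O)c2ccc(C(C)(C)C)cc2)CC1` differs from compound 1 by a group of 9 heavy atoms (8 carbon, 1 nitrogen; one five-membered non-aromatic ring with 1 hetero atom, one six-membered aromatic ring of carbon only) in place of a group of 6 heavy atoms (5 carbon, 1 nitrogen; one three-membered non-aromatic ring of carbon only, one five-membered non-aromatic ring with 1 hetero atom), on a carbonyl carbon. Among the measured compounds shown here, none of the measured steps gives a readable size, so nothing beyond the scatter is expected in this assay, and compound 4 is expected to sit at the limit as well. The estimate for compound 4 is 60000 nM, range 20000 nM to 200000 nM. The expected step that the limit leaves unreadable from compound 1 to compound 4 is accordingly flat.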

Compound 4, half-maximal effective concentration: > 40000 nM
Compound 4 ended at the assay's limit; the forecaster's own chance of this, stated with the estimate: 85%; the middle value is on the limit's open side.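

The steps linking compound 4 with compound 1, compound 2 and compound 3 cannot be read, because all four compounds stop at a limit: the limit of > 40000 nM in this assay, at which 4 of the 4 values shown sit. From the compounds shown here alone, whether any amide group on the shared core gives a sized value in this assay stays open.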